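Cyclopentyl for pyridin-2-yl on the amide-type nitrogen

The compounds below may be only part of what the source reports. "The series", "measured", "known", "first", "only" and "open" are said of these compounds alone.

In an in vitro ADME assay on microsomes from liver (Mus musculus) for pharmacokinetics, read by LC-MS, with a stated time of 10 min, tested at 1 uM (on this read-out higher numbers stand for fast clearance and lower numbers for slow clearance), compound 1 `CN1C[C@H](C(=O)Nc2ccc(Cl)c(Cl)c2)[C@@H](c2ccc(/C=C/C(=O)Nc3ccccc3N)cc2)C1` gives 36 mL/min/kg and compound 2 `CN1C[C@H](C(=O)Nc2ccccn2)[C@@H](c2ccc(/C=C/C(=O)Nc3ccccc3N)cc2)C1` gives 40 mL/min/kg so compound 2 stands within the scatter of compound 1. Compound 3 `CN1C[C@H](C(=O)NC2CCCC2)[C@@H](c2ccc(/C=C/C(=O)Nc3ccccc3N)cc2)C1` has cyclopentyl in place of pyridin-2-yl on an amide-type nitrogen and no other change. Among the compounds with values here, the one measured step at this nitrogen is a 1.1-fold higher number from compound 1 to compound 2 (0.05 log units; within the scatter) with pyridin-2-yl in place of 3,4-dichlorophenyl. Neither measured compound carries a non-aromatic ring there, so support is thin. The estimated 1.1-fold higher number from compound 2 to compound 3 (0.02 log units; within the scatter) stays within the scatter, with no direction expected. In this assay the estimate for compound 3 is 42 mL/min/kg and the expected range runs from 22 mL/min/kg to 75 mL/min/kg for now.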

Compound 3, clearance: 61 mL/min/kg
Compound 3: the middle estimate sits 1.5-fold (0.16 log units) below what was measured, within the range that was stated.
By their numbers in this assay, from the lowest: compounds 1, 2 and 3 (each within the scatter of the next).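

With cyclopentyl, a non-aromatic ring of carbon only, on the amide-type nitrogen, this assay shows a 1.5-fold higher number from compound 2 to compound 3 (0.18 log units; within the scatter) and a 1.7-fold higher number from compound 1 to compound 3 (0.23 log units; within the scatter). This position has therefore taken 3,4-dichlorophenyl, pyridin-2-yl and cyclopentyl with every step inside the scatter, so swapping an aromatic ring for this non-aromatic one gives no separable change in clearance. Nothing at hand accounts for these numbers.

Open, as far as these compounds go, is whether a group of another kind on this nitrogen, such as a carboxylic acid, a primary amine or a longer alkyl chain, would give a step beyond the scatter.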